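The compounds below may be only part of what the source reports. "The series", "measured", "known", "first", "only" and "open" are said of these compounds alone.

Working notes on the series.

The shared core carries a thioether substituent, and the three measured compounds differ only there. Compound 1 `CC(C)C(Sc1nc2c(cnn2C)c(=O)n1-c1ccccc1)c1ccccc1` gives 380 nM in an assay on isolated protein for inhibition of aldehyde dehydrogenase 1A1 (Homo sapiens); a lower number here means a stronger inhibitor, a higher number a weaker inhibitor; compound 2 `CC(Sc1nc2c(cnn2C)c(=O)n1-c1ccccc1)c1ccccn1` gives 242 nM; compound 3 `CCC(Sc1nc2c(cnn2C)c(=O)n1-c1ccccc1)c1ccccc1` gives 150 nM. Compound 3 holds the lowest number of the three, set apart from compound 1 by a 2.5-fold lower number from compound 1 to compound 3 (0.40 log units; beyond the scatter), while compound 2 sits near it, as a 1.6-fold lower number from compound 2 to compound 3 (0.21 log units; within the scatter) shows.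

Compound 4 `CC(Sc1nc2c(cnn2C)c(=O)n1-c1ccccc1)c1ccncc1` is not yet measured. Its change from compound 3 is 1-(pyridin-4-yl)ethyl in place of 1-phenylpropyl on a sulfur. Among the measured compounds shown here, the step that bears most on it is the one between compound 2 and compound 3, where a pyridin-2-yl ethyl group against the phenylpropyl group moved the number only a 1.6-fold lower number from compound 2 to compound 3 (0.21 log units; within the scatter), within the scatter; no measured pair separates the pyridin-4-yl from the pyridin-2-yl arrangement, so that part of the change is unsupported. The expectation for compound 4 is therefore a small step of a 1.7-fold higher number from compound 3 to compound 4 (0.22 log units; within the scatter) in this assay, toward a somewhat higher number but not clearly beyond the scatter. Compound 4 is estimated at 250 nM, with a range from 100 nM to 650 nM.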

Compound 4, half-maximal inhibitory concentration: 451 nM
Compound 4: the middle estimate sits 1.8-fold (0.26 log units) below what was measured, within the range that was stated.
By their numbers in this assay, from the lowest: compounds 3, 2, 1 and 4 (each within the scatter of the next, the first and the last beyond it).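

In this assay, among the compounds shown here, 1-(pyridin-4-yl)ethyl in place of 1-phenylpropyl on the sulfur gives a 3.0-fold higher number from compound 3 to compound 4 (0.48 log units; beyond the scatter) and is the first step to a pyridine-bearing group at this position that lies beyond the scatter. Pyridin-4-yl in place of pyridin-2-yl on the same chain carbon gives a 1.9-fold higher number from compound 2 to compound 4 (0.27 log units; within the scatter) and so does not by itself separate the two ring arrangements. Nothing available explains the step from compound 3 to compound 4.

That step changes the ring and the chain together, so 1-phenylethyl on the sulfur would be the group to divide the two contributions. From the compounds shown here alone, how 1-(pyridin-3-yl)ethyl or a 1-(pyridin-4-yl)propyl group would read at this position also remains open.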